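Alkylation of the ring nitrogen in the compound 2 series

The compounds below may be only part of what the source reports. "The series", "measured", "known", "first", "only" and "open" are said of these compounds alone.

Compound 2 `CN1CCN(c2nc3ccccc3[nH]2)CC1` sits at the limit of a functional assay on ileum for inhibition of histamine H1 receptor (Cavia porcellus); on this read-out higher numbers stand for weaker inhibition and lower numbers for stronger inhibition: its value is a limit, > 3000 nM (the limit of > 3000 nM in this assay, at which 1 of the 2 values shown sits), not a number. Compound 1 `CCCCN1CCCN(c2nc3ccccc3n2CCOCC)CC1` in this assay gives 8.4 nM. Compound 3 `CCCC(C)Cn1c(N2CCN(C)CC2)nc2ccccc21` has not been measured; it differs from compound 2 by 2-methylpentyl in place of hydrogen on an aromatic nitrogen. Among the compounds with values here, no measured step covers this change, so the expectation rests on the two values shown. The step from compound 2 to compound 3 is expected to be a large gain, an at least 30-fold lower number from compound 2 to compound 3 (1.47 log units; beyond the scatter). Compound 3 is therefore estimated at 100 nM, within 15 nM to 800 nM.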

Compound 3, half-maximal inhibitory concentration: 500 nM
Compound 3: middle estimate off by 5.0-fold (0.70 log units), on the low side, within the range that was stated.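

Substitution on this aromatic nitrogen pays in this assay: 2-methylpentyl in place of hydrogen gives an at least 6.0-fold lower number from compound 2 to compound 3 (0.77 log units; beyond the scatter). The full size of this gain stays open, because compound 2 is a limit and not a number: the limit of > 3000 nM in this assay, at which 1 of the 3 values shown sits.

Open, on these data alone, is how a shorter chain such as ethyl, a benzyl group or a chain ending in an amine on this nitrogen would compare with 2-methylpentyl. As far as these compounds go, compound 3 differs from compound 1 in more than one place, so the share of each change in the value of compound 1, 8.4 nM, also stays open.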